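A few compounds are considered here, and "the series" means these few. Any claim that something is new, unique, unknown or untested is made for them only; others in the source may bear on it.

Compound 1 `COc1ccc2ncc(S(=O)(=O)c3ccc(C)cc3)c(N3CCC(C)CC3)c2c1`: 90%
Compound 2 `Cc1cc(C)cc(S(=O)(=O)c2cnc3ccc(F)cc3c2N2CCC(C)CC2)c1`: 83%

Of the compounds shown here, two sharing one core have been measured in an assay on isolated protein for displacement of a labelled ligand from metabotropic glutamate receptor 5 (Homo sapiens), with a stated time of 60 min, tested at 1 uM; a lower number here means less inhibition, a higher number more inhibition at the concentration tested (going by the name of the read-out). Compound 1, which carries a methoxy group on its fused ring system, gives 90% in this assay. Compound 2, which carries a fluoro group at the same place and a different substitution pattern on the sulfonyl-bearing aryl ring, gives 83%. The two values sit within the usual scatter of each other, so on the numbers shown compound 2 stands level with compound 1; no ranking between them can be read from these data.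

Compound 3 `COc1ccc2ncc(S(=O)(=O)c3cc(C)cc(C)c3)c(N3CCC(C)CC3)c2c1` has not yet been measured. It differs from compound 2 in a single place, (methoxy in place of fluoro on an aromatic carbon). The sulfonyl-bearing aryl ring of compound 3 is that of compound 2, while the fused ring system now carries the methoxy group found in compound 1. Going by the values given here, no step between measured compounds isolates this exchange, so its size is unknown here. Since both measured compounds give high inhibition, and compound 1 with the methoxy group gives 90%, the step from compound 2 to compound 3 is expected to be small, a number 4 percentage points higher from compound 2 to compound 3 (within the scatter), and not beyond the scatter in either direction. Compound 3 is therefore estimated to give 87% in this assay, within a range of 74% to 96%.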

Compound 3, a percentage reported as inhibition, at one concentration (the size of the read-out at that concentration, not a potency): 79%
The estimate for compound 3 lay 8 percentage points above the measured number; the measured number falls inside the stated range.
By their numbers in this assay, from the lowest: compounds 3, 2 and 1 (each within the scatter of the next, the first and the last beyond it).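

In this assay, with the 3,5-dimethylphenyl group held on the sulfonyl sulfur, methoxy in place of fluoro on the aromatic carbon gives a number 4 percentage points lower from compound 2 to compound 3 (within the scatter), so the two groups cannot be told apart at this position in this pair. Going by these compounds alone, with methoxy held on the shared core, 3,5-dimethylphenyl in place of 4-methylphenyl on the sulfonyl sulfur gives a number 11 percentage points lower from compound 1 to compound 3 (beyond the scatter), and this is the only single-place step among the three compounds that lies beyond the scatter. Nothing further is available that would account for either step.

The compounds shown leave open whether the step at the sulfonyl sulfur would also appear with fluoro on the core, and how an amine or a carboxylic acid would read on the same aromatic carbon. Since each reading comes from a single tested concentration, they also leave open how these compounds would rank in full concentration-response measurements.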